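The source may hold more compounds than are shown below. What is called first, only, known or untested is meant among the compounds shown, and "the series" means these compounds.

Working notes on the series, read in a functional assay on the whole organism with Mus musculus as the target; on this read-out higher numbers stand for an effect only at larger amounts of compound and lower numbers for an effect already at smaller amounts. Compound 1 `C[C@@H](NCc1ccc(OCc2ccccc2Cl)cc1)C(N)=O` gives 17.4 mg/kg, compound 2 `C[C@@H](NCc1ccc(OCc2ccccn2)cc1)C(N)=O` gives 172 mg/kg, and compound 3 `C[C@@H](NCc1ccc(OCc2ccsc2)cc1)C(N)=O` gives 114 mg/kg. Compound 3 stands level with the pyridin-2-yl analogue, as the step of a 1.5-fold lower number from compound 2 to compound 3 (0.18 log units; within the scatter) shows, and well apart from the 2-chlorophenyl analogue, with a 6.6-fold higher number from compound 1 to compound 3 (0.82 log units; beyond the scatter).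

The next analogue is compound 4 `C[C@@H](NCc1ccc(OCc2ccoc2)cc1)C(N)=O`, and the change is furan-3-yl in place of thiophen-3-yl on a saturated chain carbon bound to an oxygen on an aromatic ring. For the measured compounds named here, no measured step makes this exact exchange. The closest evidence is the exchange of pyridin-2-yl for thiophen-3-yl, a 1.5-fold lower number from compound 2 to compound 3 (0.18 log units; within the scatter), which stays small. The larger steps, a 9.9-fold higher number from compound 1 to compound 2 (0.99 log units; beyond the scatter) and a 6.6-fold higher number from compound 1 to compound 3 (0.82 log units; beyond the scatter), both start from 2-chlorophenyl, a group that plays no part in the present change, so they bear on it only weakly. On that basis, no step beyond the scatter is expected in this assay, and no direction can be assigned from these three compounds. The estimated step is a 1.1-fold higher number from compound 3 to compound 4 (0.02 log units; within the scatter). For compound 4 the expected value is 120 mg/kg, with an estimated range of 60 mg/kg to 240 mg/kg.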

Compound 4, dose for half-maximal effect: 152 mg/kg
The estimate for compound 4 lay 1.3-fold (0.10 log units) below the measured number, and the stated range covers the measured number.
By their numbers in this assay, from the lowest: compound 1; then compounds 3, 4 and 2 (each within the scatter of the next).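

At this place, on a saturated chain carbon bound to an oxygen on an aromatic ring, this assay does not separate furan-3-yl from thiophen-3-yl (a 1.3-fold higher number from compound 3 to compound 4 (0.12 log units; within the scatter)) or from pyridin-2-yl (a 1.1-fold lower number from compound 2 to compound 4 (0.05 log units; within the scatter)), so the three groups now form one level within the scatter, across two five-membered rings with different hetero atoms and the pyridin-2-yl group. The distance to the 2-chlorophenyl group holds for this third group as well (an 8.7-fold higher number from compound 1 to compound 4 (0.94 log units; beyond the scatter)), which leaves compound 1 as the only one of the four set apart from the others. Nothing measured here accounts for this grouping or for the separate place of compound 1.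

The compounds shown leave open whether the separate place of compound 1 belongs to the chlorine or to the rest of the 2-chlorophenyl group, a question that a plain phenyl group or a chlorine carried on thiophen-3-yl would address. Also open, on these data alone, is how this place responds to groups of another kind, such as an amine, a carboxylic acid or a longer chain.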